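A few compounds are considered here, and "the series" means these few. Any claim that something is new, unique, unknown or untested is made for them only; others in the source may bear on it.

Measured compounds:
- compound 1, `CC[C@@H](Nc1c(C#N)c(-c2ccc(-c3ccccc3OC)cc2)nc2cnccc12)C(N)=O`: 2.7
- compound 2, `CC[C@@H](Nc1c(C#N)c(-c2ccc(Br)cc2)nc2cnccc12)C(N)=O`: 2.2
- compound 3, `CC[C@@H](Nc1c(C#N)c(-c2ccc(-c3cccc(Cl)c3F)cc2)nc2cnccc12)C(N)=O`: 3.1

In a physicochemical assay for lipophilicity, read by HPLC, at pH 7.5 (a lower number here means a more polar compound, a higher number a more lipophilic compound), compound 3 stands highest of the three, with compound 1 nearest and compound 2 furthest away. The three compounds share one core and differ only in the group on the outer aromatic ring. The step of a number 0.90 log units higher from compound 2 to compound 3 (beyond the scatter) and the step of a number 0.40 log units higher from compound 1 to compound 3 (beyond the scatter) both show that a second aromatic ring with halogens raises the number. Compound 4, `CC[C@@H](Nc1c(C#N)c(-c2ccc(-c3ccccc3N(C)C)cc2)nc2cnccc12)C(N)=O`, has not been measured. Compared with compound 3 it changes as follows: 2-(dimethylamino)phenyl in place of 3-chloro-2-fluorophenyl on an aromatic carbon. The most relevant comparison is compound 1, whose 2-methoxyphenyl group likewise carries a hydrogen-bond acceptor and which gives 2.7 in this assay. The step of a number 0.40 log units higher from compound 1 to compound 3 (beyond the scatter) sets the size of what a change of this kind can do. Compound 4 is therefore expected to land between compound 1 and compound 3, with a step of a number 0.20 log units lower from compound 3 to compound 4 (within the scatter) that may not exceed the scatter. The estimate for compound 4 is 2.9, in the range 2.5 to 3.3.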

Compound 4, distribution coefficient: 3.2
The estimate for compound 4 lay 0.30 log units below the measured number, within the range that was stated.
By their numbers in this assay, from the lowest: compound 2; then compound 1; then compounds 3 and 4 (each within the scatter of the next).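

In this assay, dimethylamino in place of methoxy gives a number 0.50 log units higher from compound 1 to compound 4 (beyond the scatter), so a single small change on the second aromatic ring can matter at this position. A hydrogen-bond acceptor in the entering group does not by itself keep the number low here: 2-(dimethylamino)phenyl in place of 3-chloro-2-fluorophenyl, which has no such acceptor, gives a number 0.10 log units higher from compound 3 to compound 4 (within the scatter), so the two cannot be told apart. The second ring also need not carry halogens to stand well clear of bromo, as 2-(dimethylamino)phenyl in place of bromo gives a number 1.00 log units higher from compound 2 to compound 4 (beyond the scatter).

No measurement shown here accounts for the difference between the dimethylamino and methoxy compounds. On these data alone, it remains open how the number would respond to a carboxylic acid or a primary amine on the second ring, or to a morpholine in place of the dimethylamino group.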